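The source may hold more compounds than are shown below. What is called first, only, known or untested is meant among the compounds shown, and "the series" means these compounds.

Compound 1 `COc1cc2ncnc(Nc3cccc(Cl)c3)c2cc1OCCCN1CCNCCNCCNCC1` in a functional assay on A549 cells (Homo sapiens) for antiproliferative activity, read by MTT assay, with a stated time of 72 h (on this read-out lower numbers stand for stronger inhibition and higher numbers for weaker inhibition), gives 27100 nM. Compound 2 `COc1cccc(Nc2ncnc3cc(OC)c(OCCCN4CCNCCNCCNCC4)cc23)c1` in this assay returns only a limit, > 50000 nM. Compound 3 `COc1cc2ncnc(Nc3cccc(Cl)c3)c2cc1OCCCN1CCNCCNCC1` in this assay likewise returns a limit, > 50000 nM. The change methoxy in place of chloro on an aromatic carbon gave an at least 1.8-fold higher number from compound 1 to compound 2 (0.26 log units; that floor lies within the scatter). Compound 4 `COc1cccc(Nc2ncnc3cc(OC)c(OCCCN4CCNCCNCC4)cc23)c1` carries the same change, (methoxy in place of chloro on an aromatic carbon), on the core of compound 3; the two cores differ by a group of 9 heavy atoms (6 carbon, 3 nitrogen; one nine-membered non-aromatic ring with 3 hetero atoms) in place of a group of 12 heavy atoms (8 carbon, 4 nitrogen; one twelve-membered non-aromatic ring with 4 hetero atoms), on a saturated chain carbon, three bonds along the chain from an oxygen on an aromatic ring, while the place of the change reads the same in both pairs. Because compound 3 already sits at the limit of > 50000 nM in this assay, at which 2 of the 3 values shown sit, the step expected for the same change is a step that the limit leaves unreadable from compound 3 to compound 4, in line with an at least 1.8-fold higher number from compound 1 to compound 2 (0.26 log units; that floor lies within the scatter). For compound 4 the expected value in this assay is 80000 nM, between 40000 nM and 200000 nM, with a limit rather than a number the most likely report.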

Compound 4, half-maximal inhibitory concentration: > 50000 nM
Compound 4 ended at the assay's limit; the forecaster's own chance of this, stated with the estimate: 85%; the middle value lies beyond the limit too.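

No new step can be read: compound 2, compound 3 and compound 4 all return only limits in this assay. Still open, as far as these compounds go, is whether methoxy in place of chloro shifts activity on the core of compound 3, and what the nine-membered ring does in the methoxy pair.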